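Fluoro to amino at a cytotoxicity limit

A few compounds are considered here, and "the series" means these few. Any claim that something is new, unique, unknown or untested is made for them only; others in the source may bear on it.

In an ADME assay on HepG2 cells (Homo sapiens) for cytotoxicity, read by MTT assay, with a stated time of 72 h (a higher number here means that more compound is tolerated, a lower number that less compound is tolerated), compound 1 (`COc1ccccc1C#Cc1cc(Cl)cn2c([N+](=O)[O-])c(CS(=O)(=O)c3ccccc3)nc12`) gives only a limit, > 3900 nM. Compound 2 (`O=[N+]([O-])c1c(CS(=O)(=O)c2ccccc2)nc2c(C#Cc3ccc(F)cc3)cc(Cl)cn12`) also gives only a limit, > 3900 nM. Both compounds stand at the limit of > 3900 nM in this assay, at which 2 of the 2 values shown sit, so no exact position is known for compound 2. For the measured compounds named here, the one measured change is a step that the two limits leave unreadable from compound 1 to compound 2, and it supplies no size to carry forward. Compound 3 (`Nc1ccc(C#Cc2cc(Cl)cn3c([N+](=O)[O-])c(CS(=O)(=O)c4ccccc4)nc23)cc1`) differs from compound 2 by amino in place of fluoro on an aromatic carbon, with amino in place of fluoro on an aromatic carbon. With no readable step as a guide, no clear shift in either direction is expected. The estimated step is a step that the limit leaves unreadable from compound 2 to compound 3. For compound 3, the expected value is 6000 nM, with an estimated range from 2500 nM to 20000 nM.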

Compound 3, half-maximal cytotoxic concentration: > 3900 nM
Compound 3: a limit, no number; the forecaster's own chance of this, stated with the estimate: 60%; the middle value does not contradict the limit.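

No step can be read between compound 1, compound 2 and compound 3, because each gives only a limit and not a number: the limit of > 3900 nM in this assay, at which 3 of the 3 values shown sit.

The compounds shown leave open how much of each compound the cells tolerate, and whether amino in place of fluoro shifts that at all.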